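The compounds below may be only part of what the source reports. "The series", "measured", "known", "first", "only" and "open" are said of these compounds alone.

Measured so far:
compound 1 `COc1ccc(-c2nn(-c3ccccc3)cc2C(=O)NOCc2ccccc2Cl)cc1` — 2450 nM
compound 2 `O=C(NOCc1ccccc1)c1cn(-c2ccccc2)nc1-c1ccc(F)cc1` — 10400 nM
compound 3 `O=C(NOCc1ccccc1F)c1cn(-c2ccccc2)nc1-c1ccc(F)cc1` — 17500 nM

All three numbers come from a functional assay on A549 cells (Homo sapiens) for antiproliferative activity, read by MTT assay, with a stated time of 48 h, in the presence of a further agent that is not named here; on this read-out lower numbers stand for stronger inhibition of growth and higher numbers for weaker inhibition of growth. Among them compound 3 stands at the highest number. Its nearest neighbour is compound 2, and the step of a 1.7-fold higher number from compound 2 to compound 3 (0.23 log units; within the scatter) lies within the scatter, so the two are not distinguished. Among the measured compounds shown here, compound 1 lies furthest away, at a number beyond the scatter lower than that of compound 3, but compound 1 differs from compound 3 in two places at once and no single step connects them.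

Compound 4 `O=C(NOCc1ccccc1Cl)c1cn(-c2ccccc2)nc1-c1ccc(F)cc1` differs from compound 3 by chloro in place of fluoro on an aromatic carbon. For the measured compounds named here, no measured step exchanges fluoro for chloro at this position. Going by the values given here, the only measured step at the same place, a 1.7-fold higher number from compound 2 to compound 3 (0.23 log units; within the scatter), is small and within the scatter, which gives no reason to expect a large move from a second halogen exchange there. Compound 1 carries the same 2-chlorobenzyl and gives the lowest number of the set, but its other change is not separated by any step, so it cannot be weighed on its own. The step from compound 3 to compound 4 is therefore expected to be modest, a 1.8-fold lower number from compound 3 to compound 4 (0.24 log units; within the scatter), with compound 1 left as the one hint of a larger move downward. For compound 4 the estimated value in this assay is 10000 nM, with a range from 3500 nM to 30000 nM.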

Compound 4, concentration for 50% growth inhibition: 8330 nM
Estimate against measurement, compound 4: 1.2-fold (0.08 log units) above; the range from low to high includes it.
By their numbers in this assay, from the lowest: compound 1; then compounds 4, 2 and 3 (each within the scatter of the next, the first and the last beyond it).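

In this assay, among the compounds shown here, exchanging 2-fluorobenzyl for 2-chlorobenzyl gives a 2.1-fold lower number from compound 3 to compound 4 (0.32 log units; beyond the scatter), the first step at this position to lie beyond the scatter, yet the same chloro group set against hydrogen gives only a 1.2-fold lower number from compound 2 to compound 4 (0.10 log units; within the scatter), so the position separates the two halogens from each other while neither is separated from hydrogen. With 2-chlorobenzyl now held constant, the change elsewhere can be read on its own: fluoro in place of methoxy gives a 3.4-fold higher number from compound 1 to compound 4 (0.53 log units; beyond the scatter), a larger step than any measured at the benzyl position, which places the low number of compound 1 with its methoxy group and not with its chloro group. No measurement accompanies these steps that would say what lies behind them.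

Open, going by these compounds, is whether the methoxy step holds with hydrogen or fluoro on the benzyl group, since methoxy appears here only alongside chloro. Also open is how this position responds to a group of a different kind, such as an amine or a carboxylic acid, since only hydrogen and two halogens are shown there.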